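The source may report more compounds than this note shows. Statements on the series, on what has been measured and on what is new or still open speak of the compounds shown alone.

Measured in a functional assay on MV4-11 cells (Homo sapiens) for inhibition, read by resazurin assay, with a stated time of 72 h; on this read-out lower numbers stand for stronger inhibition of growth and higher numbers for weaker inhibition of growth:
- compound 1 `NS(=O)(=O)c1cccc(Nc2ncc3c(n2)CCCC3)c1` gives 2550 nM
- compound 2 `O=[N+]([O-])c1cccc(Nc2ncc3c(n2)CCCC3)c1` gives 3500 nM
- compound 3 `COc1ccc(Nc2ncc3c(n2)CCC3)cc1` gives 840 nM

Compound 1 sits level with compound 2 within the scatter, and the number for compound 3 lies lower than that of compound 1, beyond the scatter. The next compound to be read in this assay is compound 4 `CCc1cccc(Nc2ncc3c(n2)CCCC3)c1`. It differs from compound 1 in one place, with ethyl in place of sulfamoyl on an aromatic carbon.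

For the measured compounds named here, only one measured step bears directly on this change. Nitro in place of sulfamoyl gave a 1.4-fold higher number from compound 1 to compound 2 (0.14 log units; within the scatter), so that exchange at this place left the number within the scatter. Going by the values given here, compound 3 differs from compound 1 in more than one place and gives no clean step for this change. Among the compounds with values here, no measured compound carries ethyl, so the evidence for this group is indirect and the range has to stay wide. A step beyond the scatter is not expected, in either direction. The expected step is a 1.2-fold lower number from compound 1 to compound 4 (0.06 log units; within the scatter). For compound 4 the estimated value is 2200 nM, with an expected range of 800 nM to 6000 nM.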

Compound 4, concentration for 50% growth inhibition: 2600 nM
For compound 4 the middle estimate is 1.2-fold (0.07 log units) below the measured one; the range from low to high includes it.
By their numbers in this assay, from the lowest: compound 3; then compounds 1, 4 and 2 (each within the scatter of the next).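

In this assay, ethyl in place of sulfamoyl on this aromatic carbon, meta to a large group, gives a 1.0-fold higher number from compound 1 to compound 4 (0.01 log units; within the scatter), and ethyl in place of nitro gives a 1.3-fold lower number from compound 2 to compound 4 (0.13 log units; within the scatter). Before this result, only the exchange of sulfamoyl for nitro had been read at this place; now a group of two carbon atoms with 0 hydrogen-bond donors and 0 hydrogen-bond acceptors also stays level with both, so the hydrogen-bond donor and acceptors of sulfamoyl can leave with no step beyond the scatter. Across compounds 1, 2 and 4 the number at this place therefore holds level with all three groups, and no measurement shown here accounts for that.

As far as these compounds go, whether an amine, a carboxylic acid or a longer chain on this aromatic carbon would also stay within the scatter remains open, so the limits of this tolerance are not yet defined. Also open, from the compounds shown here alone, is whether sulfamoyl, nitro and ethyl would stay level with one another on a core other than the core of compound 1.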